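The source may report more compounds than this note shows. Statements on the series, on what has been measured and on what is new or still open speak of the compounds shown alone.

Compound 1 `ClCc1ccc(Cn2cnc3c(Cl)ncnc32)cc1`: in a functional assay on UACC-62 cells (Homo sapiens) for cytotoxicity, read by sulforhodamine B assay, with a stated time of 48 h (on this read-out higher numbers stand for weaker inhibition of growth and lower numbers for stronger inhibition of growth), compound 1 gives 33900 nM.
Compound 2 `ClCc1cccc(Cn2cnc3c(Cl)nc(Cl)nc32)c1`: compound 2 gives 3460 nM.

Compound 2 holds the lowest of the two numbers in this assay; the nearest, compound 1, lies far higher, beyond the scatter. Within the data shown here, compounds 1 and 2 differ in more than one place, so no single step between them is resolved. The next compound, compound 3 `Nc1nc(Cl)c2ncn(Cc3cccc(CCl)c3)c2n1`, is compound 2 with amino in place of chloro on an aromatic carbon. Among the measured compounds shown here, no measured pair isolates this change, so its direction in this assay is open; a step of modest size is expected, if anything toward weaker inhibition. The step expected here is a 1.7-fold higher number from compound 2 to compound 3 (0.24 log units; within the scatter). Compound 3 is estimated at 6000 nM, between 1500 nM and 25000 nM.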

Compound 3, concentration for total growth inhibition: 4780 nM
Beside the measured number, compound 3's estimate is 1.3-fold (0.10 log units) above it; the measured number falls inside the stated range.
By their numbers in this assay, from the lowest: compounds 2 and 3 (each within the scatter of the next); then compound 1.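

Among these compounds, the swap of chloro for amino on the aromatic carbon between two ring nitrogen atoms gives the first single-place step, a 1.4-fold higher number from compound 2 to compound 3 (0.14 log units; within the scatter), in this assay. Compounds 2 and 3 cannot be told apart here, so this position accepts either group without a resolved shift in growth inhibition. Nothing available accounts for this result.

On these data alone, whether a methoxy or dimethylamino group at this position would hold the same level remains open. Also open, as far as these compounds go, is what a plain hydrogen there would give with the rest of compound 2 unchanged.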